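Moving the nitro group on the urea phenyl ring

The source may report more compounds than this note shows. Statements on the series, on what has been measured and on what is new or still open speak of the compounds shown alone.

Three members of this series have numbers in a physicochemical assay, with a stated time of 6 min (a higher number here means a weaker inhibitor, a lower number a stronger inhibitor), and they span a wide range. Compound 1, `Cc1ccc(NC(=O)Nc2nc(-c3cc4ccccc4o3)cs2)cc1`, gives 500 nM in this assay. Compound 3, `O=C(Nc1ccc(Cl)cc1)Nc1nc(-c2cc3cc([N+](=O)[O-])ccc3o2)cs1`, is far weaker, at 117000 nM. Among the measured compounds shown here, compound 2, `O=C(Nc1ccc([N+](=O)[O-])cc1)Nc1nc(-c2cc3cc(Br)ccc3o2)cs1`, is the one that the next step starts from, and it stands at the bottom of the set: in this assay it gives only a limit, > 200000 nM, at the limit of > 200000 nM in this assay, at which 1 of the 3 values shown sits. No real inhibition was measured for compound 2, only the boundary of the assay.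

Compound 4, `O=C(Nc1nc(-c2cc3cc(Br)ccc3o2)cs1)Nc1ccccc1[N+](=O)[O-]`, keeps every atom of compound 2 but joins them differently: 2-nitrophenyl in place of 4-nitrophenyl on an amide-type nitrogen. The nitro group thus stays on the same phenyl ring, only its place on that ring moves. For the measured compounds named here, no pair of measured compounds differs in this single way, so there is no measured step to lean on. The two compounds that carry a nitro group, compound 2 and compound 3, are both very weak, and a move of the nitro group within the same ring is not expected to undo that; at most a modest change is expected in the step of an at least 1.3-fold lower number from compound 2 to compound 4 (0.12 log units; that floor lies within the scatter). Compound 4 is therefore estimated at 150000 nM, within a range from 30000 nM to 300000 nM, with a real chance that only a limit is reported again.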

Compound 4, half-maximal inhibitory concentration: 166000 nM
Compound 4: middle estimate off by 1.1-fold (0.04 log units), on the low side, and the stated range covers the measured number.
By their numbers in this assay, from the lowest: compound 1; then compounds 3 and 4 (each within the scatter of the next). At a limit, above all of these: compound 2.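

With the 2-nitrophenyl group on the amide-type nitrogen, compound 4 gives a real reading in this assay of 166000 nM, which shows that the nitro group can move on this ring and the series still returns a number. Compound 2 remains a limit of the assay and not a number: the limit of > 200000 nM in this assay, at which 1 of the 4 values shown sits. Moving the nitro group gives an at least 1.2-fold lower number from compound 2 to compound 4 (0.08 log units; that floor lies within the scatter); the true size of the change stays unknown, and no gain beyond the scatter can be claimed, leaving the move with no visible sign of rescuing this very weak compound.

The compounds shown leave open what happens on this phenyl ring when an amine or a carboxylic acid takes the place of the nitro group while the rest of compound 4 stays the same. Compound 4 also differs from compound 1 in more than one place, and which of those places accounts for the value of compound 1, 500 nM, remains unresolved.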